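The compounds below may be only part of what the source reports. "The series", "measured", "known", "first", "only" and "open" are said of these compounds alone.

Working notes on the series. Three compounds have numbers in a functional assay on A549 cells (Homo sapiens) for antiproliferative activity, read by MTT assay, with a stated time of 72 h; a lower number here means a stronger inhibitor, a higher number a weaker inhibitor. Compound 1 `COc1cc2c(Oc3ccc(NC(=O)NN4C(=O)CSC4c4c(F)cccc4F)c(Cl)c3)ccnc2cc1OCCCN1CCCC1` gives 960 nM in this assay. Compound 2 `COc1cc2c(Oc3c(F)cc(NC(=O)NN4C(=O)C(C)SC4c4c(F)cccc4F)cc3F)ccnc2cc1OCCCN1CCCC1` gives 830 nM in this assay. Compound 3 `CCN1CCN(CCCOc2cc3nccc(Oc4c(F)cc(NC(=O)NN5C(=O)CSC5c5c(F)cccc5F)cc4F)c3cc2OC)CC1` gives 350 nM in this assay, the lowest of the three numbers; its gap to compound 2 and its wider gap to compound 1 both lie beyond the usual scatter, so compound 3 is the most potent of the three measured.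

Compound 4 `CCN(CC)CCCOc1cc2nccc(Oc3c(F)cc(NC(=O)NN4C(=O)CSC4c4c(F)cccc4F)cc3F)c2cc1OC` has not yet been measured. It differs from compound 3 in one place: diethylamino in place of 4-ethylpiperazin-1-yl on a saturated chain carbon, three bonds along the chain from an oxygen on an aromatic ring. Within the data shown here, no pair of measured compounds differs by this change alone, so there is no measured step to read the size from. The expectation is a small step, most likely within the scatter or a little toward a higher number, with the step from compound 3 estimated as a 1.4-fold higher number from compound 3 to compound 4 (0.15 log units; within the scatter). Compound 4 is accordingly estimated at 500 nM in this assay, with a range from 200 nM to 1500 nM.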

Compound 4, half-maximal inhibitory concentration: 450 nM
Compound 4: the middle estimate sits 1.1-fold (0.05 log units) above what was measured; measured number inside the range.
By their numbers in this assay, from the lowest: compounds 3, 4, 2 and 1 (each within the scatter of the next, the first and the last beyond it).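

Among these compounds, this is the first measured step at this position. In this assay, diethylamino in place of 4-ethylpiperazin-1-yl on a saturated chain carbon, three bonds along the chain from an oxygen on an aromatic ring, gives a 1.3-fold higher number from compound 3 to compound 4 (0.11 log units; within the scatter), so losing the six-membered ring and its second nitrogen, with the heavy-atom count falling from 8 to 5, leaves the number within the scatter in this pair. No measurement in hand bears on why this exchange makes so little difference.

Among the compounds shown here, compound 1 and compound 2 each differ from compound 3 and compound 4 in more than one place, so no further step at this position can be read from them. On these data alone, whether the same holds for morpholin-4-yl, dimethylamino or a primary amine at this position, or for a chain longer than 3-(diethylamino)propyl, stays open.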